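Trifluoromethyl for methyl on an arylhydrazone, whole-animal inhibition

This account rests on a few compounds, and the source may have more. Where it says the series, first, only, none or still open, it means among the compounds named here.

Measured compounds in a functional assay on the whole organism for inhibition, with Rattus norvegicus as the target; a higher number here means that more compound is needed for the effect, a lower number that less compound is needed:
compound 1, `Cc1ccccc1N/N=C1\CCC(C)n2c1ncc(C(=O)O)c2=O`, a limit of > 100 umol/kg
compound 2, `Cc1ccc(N/N=C2\CCC(C)n3c2ncc(C(=O)O)c3=O)cc1`, a limit of > 1000 umol/kg
compound 3, `CC1CC/C(=N\Nc2ccccc2C(F)(F)F)c2ncc(C(=O)O)c(=O)n21`, a limit of > 1000 umol/kg

All three values are limits of this assay, not numbers. The change from compound 1 to compound 3 is trifluoromethyl in place of methyl on an aromatic carbon; it yields a step that the two limits leave unreadable from compound 1 to compound 3, since the limit of > 100 umol/kg in this assay, at which 1 of the 3 values shown sits, and the limit of > 1000 umol/kg in this assay, at which 2 of the 3 values shown sit, bound that step on both sides. The two cores differ by 4-methylphenyl in place of 2-methylphenyl on an amine nitrogen, and that comparison gives a step that the two limits leave unreadable from compound 1 to compound 2. Compound 4, `CC1CC/C(=N\Nc2ccc(C(F)(F)F)cc2)c2ncc(C(=O)O)c(=O)n21`, is not yet measured; it differs from compound 2 by trifluoromethyl in place of methyl on an aromatic carbon. The surroundings of the place differ: ortho to a large group in the one, para to a large group in the other, so this is the same kind of change, not the same. Beside the unreadable earlier step, the step from compound 2 to compound 4 is expected to be a step that the limit leaves unreadable from compound 2 to compound 4, resting on compound 2 standing at the limit of > 1000 umol/kg in this assay, at which 2 of the 3 values shown sit. Compound 4 is expected to give 1500 umol/kg in this assay .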

Compound 4, dose for 50% inhibition: > 1000 umol/kg
Compound 4: only a limit was reported (the forecaster's own chance of this, stated with the estimate: 85%); the middle value lies beyond the limit too.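

In this assay, within the data shown here, compound 4 gives only a limit, > 1000 umol/kg, and compound 2 also stands at a limit, so no step between them can be read. The compounds shown leave open what dose any of them needs for the effect.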